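This account rests on a few compounds, and the source may have more. Where it says the series, first, only, none or still open, it means among the compounds named here.

Measured so far in a functional assay on K562 cells (Homo sapiens) for cytotoxicity, read by fluorescence, with a stated time of 72 h (a lower number here means a stronger inhibitor, a higher number a weaker inhibitor), are three compounds
- compound 1 `CC(C)c1n[nH]c2c(NCc3ccc(-c4ccccn4)cc3)nc(NCCO)nc12` gives 38 nM here
- compound 2 `CC(C)c1n[nH]c2c(NCc3ccc(-c4ccccn4)cc3)nc(N[C@@H]3CCCC[C@H]3N)nc12` gives 175 nM here
- compound 3 `CC(C)c1n[nH]c2c(NCc3ccc(-c4ccccn4)cc3)nc(NCC(N)CO)nc12` gives 700 nM here

Compound 3 has the highest number of the three, so it is the weakest inhibitor, and compound 2 is its nearest neighbour. Compound 4 `CC(C)c1n[nH]c2c(NCc3ccc(-c4ccccn4)cc3)nc(N[C@H]3CC[C@H](N)CC3)nc12` differs from it by one swap 4-aminocyclohexyl in place of 2-amino-3-hydroxypropyl on a nitrogen on an aromatic ring with 4-aminocyclohexyl in place of 2-amino-3-hydroxypropyl on a nitrogen on an aromatic ring. The closest guide is compound 2, which carries 2-aminocyclohexyl, and a 4.0-fold higher number from compound 2 to compound 3 (0.60 log units; beyond the scatter) is a modest step. The large 18-fold higher number from compound 1 to compound 3 (1.27 log units; beyond the scatter) shows how far this group can move the number. Going by the values given here, no measured compound carries 4-aminocyclohexyl, so the range stays wide. A modest fall is expected, with a 4.1-fold lower number from compound 3 to compound 4 (0.61 log units; beyond the scatter) as the estimated step in this assay here. For compound 4 the estimate is 170 nM with an expected range from 50 nM to 550 nM in this test.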

Compound 4, half-maximal inhibitory concentration: 593 nM
Compound 4: middle estimate off by 3.5-fold (0.54 log units), on the low side; the measured number lies above the stated range.
By their numbers in this assay, from the lowest: compound 1; then compound 2; then compounds 4 and 3 (each within the scatter of the next).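

The step of a 1.2-fold lower number from compound 3 to compound 4 (0.07 log units; within the scatter) shows that a six-membered ring in place of the open chain brings no clear gain here. The step of a 3.4-fold higher number from compound 2 to compound 4 (0.53 log units; beyond the scatter) shows that the position of the amine on the cyclohexyl ring matters, with the 2-amino arrangement giving the lower number. The step of a 16-fold higher number from compound 1 to compound 4 (1.19 log units; beyond the scatter) leaves both amine-bearing rings well behind the 2-hydroxyethyl group of compound 1.

Nothing measured here explains these steps. On these data alone, whether a 4-hydroxycyclohexyl group, with a hydroxyl in place of the amine, would approach compound 1 stays open.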